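This account rests on a few compounds, and the source may have more. Where it says the series, first, only, none or still open, it means among the compounds named here.

Of the compounds shown here, two sharing one core have been measured in a functional assay on HaCaT cells (Homo sapiens) for cytotoxicity, read by MTT assay, with a stated time of 48 h (on this read-out lower numbers stand for stronger inhibition and higher numbers for weaker inhibition), and they lie far apart. Compound 1 `CCC(CC)(c1ccc(OCC(O)C(C)(C)C)c(C)c1)c1ccc(C(=O)N[C@@H](C)CO)n1C` gives 15700 nM while compound 2 `CCC(CC)(c1ccc(OCC(O)C(C)(C)C)c(C)c1)c1ccc(C(=O)N[C@H](CO)CCO)n1C` gives 190 nM and so holds the lower of the two numbers. Among the compounds with values here, the only measured step is an 83-fold lower number from compound 1 to compound 2 (1.92 log units; beyond the scatter) and it is large and beyond the scatter, with hydroxymethyl replacing hydrogen on a saturated chain carbon, two bonds along the chain from an amide-type nitrogen. Compound 3 `CCC(CC)(c1ccc(OCC(O)C(C)(C)C)c(C)c1)c1ccc(C(=O)NCC(=O)O)n1C` carries carboxymethyl in place of 3-hydroxy-1-(hydroxymethyl)propyl on an amide-type nitrogen. Within the data shown here, no measured compound holds carboxymethyl, so the evidence is thin. Among the measured compounds shown here, with an 83-fold lower number from compound 1 to compound 2 (1.92 log units; beyond the scatter) as the only guide, a clear rise from compound 2 is expected, probably smaller than that measured step. The expected step is a 7.9-fold higher number from compound 2 to compound 3 (0.90 log units; beyond the scatter) and it remains uncertain. The estimated value for compound 3 is 1500 nM with a likely range from 150 nM to 15000 nM for this measurement.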

Compound 3, half-maximal inhibitory concentration: 9810 nM
Compound 3: middle estimate off by 6.5-fold (0.82 log units), on the low side, and the stated range covers the measured number.
By their numbers in this assay, from the lowest: compound 2; then compounds 3 and 1 (each within the scatter of the next).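

In this assay, carboxymethyl in place of 3-hydroxy-1-(hydroxymethyl)propyl on the amide-type nitrogen gives a large change (a 52-fold higher number from compound 2 to compound 3 (1.71 log units; beyond the scatter)), so the low number of compound 2 is lost with this second, quite different group as well. Carboxymethyl in place of 1-(hydroxymethyl)ethyl gives only a small difference (a 1.6-fold lower number from compound 1 to compound 3 (0.20 log units; within the scatter)) that lies within the scatter, so these two groups cannot be told apart here and only compound 2 stands clear of the others. Nothing at hand explains why this one group stands apart.

Going by these compounds, it remains open whether compound 2 needs both the hydroxy and the hydroxymethyl parts of its group. An amine in place of either hydroxyl, or a longer chain carrying them, could show which part matters.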